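Cytotoxicity limits on Vero cells across three aryl variants

This account rests on a few compounds, and the source may have more. Where it says the series, first, only, none or still open, it means among the compounds named here.

Compound 1, `Cn1c(CO[C@@H]2COc3nc([N+](=O)[O-])cn3C2)cnc1-c1ccc(C(F)(F)F)cc1`, in an ADME assay on Vero cells (Chlorocebus sabaeus) for cytotoxicity, with a stated time of 72 h; a lower number here means a stronger inhibitor, a higher number a weaker inhibitor: > 128000 nM, a limit of the assay.
Compound 2, `Cn1c(CO[C@@H]2COc3nc([N+](=O)[O-])cn3C2)cnc1-c1ccc(C#N)cc1`, in this assay: > 128000 nM, a limit of the assay.
Compound 3, `Cn1c(CO[C@@H]2COc3nc([N+](=O)[O-])cn3C2)cnc1-c1ccc(OC(F)(F)F)cc1`, in this assay: > 128000 nM, a limit of the assay.

Compound 2 stands at the same limit as the other two; in this assay no number is read for it, only a limit, and this is true of all three values shown, as the limit of > 128000 nM in this assay, at which 3 of the 3 values shown sit, records. The structural change to compound 4, `COc1ccc(-c2ncc(CO[C@@H]3COc4nc([N+](=O)[O-])cn4C3)n2C)cc1F`, is 3-fluoro-4-methoxyphenyl in place of 4-cyanophenyl on an aromatic carbon. For the measured compounds named here, the steps that bear on it are those that swap the group on the same phenyl ring: a step that the two limits leave unreadable from compound 1 to compound 2, a step that the two limits leave unreadable from compound 2 to compound 3 and a step that the two limits leave unreadable from compound 1 to compound 3, none of them of readable size, since every value involved is a limit. Going by the values given here, no step on this aryl position has yet produced a number, so no direction can be expected for the step from compound 2 to compound 4 beyond the scatter. Compound 4 is therefore expected to sit again at the limit, an estimate of 200000 nM with a range from 128000 nM to 500000 nM, the estimated step being a step that the limit leaves unreadable from compound 2 to compound 4.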

Compound 4, half-maximal inhibitory concentration: > 128000 nM
Compound 4: no number, only a limit (the forecaster's own chance of this, stated with the estimate: 90%); the middle value does not contradict the limit.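

Compound 4, like compound 1 and compound 2, gives no number in this assay, so neither the step from compound 2 nor the step from compound 1 to it can be read, and all values remain at a limit of the assay: the limit of > 128000 nM in this assay, at which 4 of the 4 values shown sit.

The compounds shown leave open whether swapping these groups on the phenyl ring changes the result in this assay at all.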